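This account rests on a few compounds, and the source may have more. Where it says the series, first, only, none or still open, it means among the compounds named here.

Three compounds share one core: a urea joining a di-isopropyl-substituted aniline to a five-membered carbon ring that carries an aromatic group. In an assay on microsomes for inhibition of acyl-CoA:cholesterol acyltransferase (Oryctolagus cuniculus) (a lower number here means a stronger inhibitor, a higher number a weaker inhibitor), compound 1 `Cc1ccccc1C1(CNC(=O)Nc2c(C(C)C)cccc2C(C)C)CCCC1` gives 17 nM, compound 2 `COc1cccc(C2(CNC(=O)Nc3c(C(C)C)cccc3C(C)C)CCCC2)c1` gives 13 nM, and compound 3 `CC(C)c1cccc(C(C)C)c1NC(=O)NCC1(c2cccc(OCc3ccccc3)c2)CCCC1` gives 30 nM. Compound 2 shows the lowest number of the three, though its gap to compound 1 lies within the scatter, so those two cannot be ranked; only compound 3 sits clearly higher. Compound 4 `CC(C)c1cccc(C(C)C)c1NC(=O)NCC1(c2ccc([N+](=O)[O-])cc2)CCCC1` differs from compound 2 by 4-nitrophenyl in place of 3-methoxyphenyl on a saturated ring carbon. Among the measured compounds shown here, the steps that bear on this are a 1.3-fold lower number from compound 1 to compound 2 (0.12 log units; within the scatter) and a 2.3-fold higher number from compound 2 to compound 3 (0.36 log units; beyond the scatter), both small, and neither brings in the group that enters here. A change no larger than the scatter is therefore expected. Compound 4 is estimated at 20 nM, between 8 nM and 50 nM, an expected 1.5-fold higher number from compound 2 to compound 4 (0.19 log units; within the scatter).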

Compound 4, half-maximal inhibitory concentration: 131 nM
Estimate against measurement, compound 4: 6.6-fold (0.82 log units) below; measured number above the stated range.
By their numbers in this assay, from the lowest: compounds 2, 1 and 3 (each within the scatter of the next, the first and the last beyond it); then compound 4.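

Among the compounds shown here, the group on the saturated ring carbon matters more than the earlier compounds suggested. Their changes there moved the number little, whereas in this assay 4-nitrophenyl brings a 10-fold higher number from compound 2 to compound 4 (1.00 log units; beyond the scatter) and a 7.7-fold higher number from compound 1 to compound 4 (0.89 log units; beyond the scatter), so this position does not accept every substituted phenyl equally. No measurement here offers a reason for this rise. Compound 4 differs from compound 2 in both the group on the phenyl ring and where it sits, so these two changes cannot be separated. As far as these compounds go, whether an amine or a nitrile in place of the nitro group would give a similar number also remains open.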